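Exchanging one side chain on the core of compound 1

The source may report more compounds than this note shows. Statements on the series, on what has been measured and on what is new or still open speak of the compounds shown alone.

Among the compounds with values here, compound 1 (`CC(C)(C)N(CC(=O)N(Cc1ccccc1)C1(C(=O)NCc2ccccc2)CCN(Cc2ccccc2)CC1)C(=O)O`) is the only compound here with a measured number: in a functional assay on CCRF-CEM cells (Homo sapiens) for inhibition, with a stated time of 72 h (a higher number here means a weaker inhibitor, a lower number a stronger inhibitor), compound 1 gives 21000 nM. Compound 2 (`CC[C@@H](C)[C@H](NC(=O)OC(C)(C)C)C(=O)N(C1CC1)C1(C(=O)NC(C)(C)C)CCN(Cc2ccccc2)CC1`) carries no number, only a limit of the assay, > 250000 nM. Within the data shown here, no step between measured compounds is available, so nothing yet shows how far a single change moves this assay.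

Compound 3 (`COC(=O)C[C@H](N)C(=O)N(Cc1ccccc1)C1(C(=O)NCc2ccccc2)CCN(Cc2ccccc2)CC1`) keeps the core of compound 1 and differs in one place, on a carbonyl carbon. There, 1-amino-2-(methoxycarbonyl)ethyl stands in place of (carboxy(tert-butyl)amino)methyl, and the entering group has one defined stereocentre: 1-amino-2-(methoxycarbonyl)ethyl in place of (carboxy(tert-butyl)amino)methyl on a carbonyl carbon.

Among the measured compounds shown here, with no measured step as a guide, the expectation rests on compound 1 and its 21000 nM, the sole numerical anchor. The expected step, a 1.4-fold higher number from compound 1 to compound 3 (0.15 log units; within the scatter), is no larger than the usual scatter, with a slight lean toward weaker inhibition, though a larger move in either direction cannot be excluded. Compound 3 is estimated at 30000 nM, with an expected range from 8000 nM to 120000 nM.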

Compound 3, half-maximal inhibitory concentration: 104000 nM
Compound 3: the middle estimate sits 3.5-fold (0.54 log units) below what was measured; low and high end bracket the measured number.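

This exchange gives the series its first readable step: in this assay, 1-amino-2-(methoxycarbonyl)ethyl in place of (carboxy(tert-butyl)amino)methyl, on a carbonyl carbon whose other neighbour is an amide-type nitrogen, gives a 5.0-fold higher number from compound 1 to compound 3 (0.69 log units; beyond the scatter). The position is therefore not silent in this read-out, and this change moves it toward weaker inhibition by more than the usual scatter. Compound 2 gives only a limit of the assay and not a number, so it adds no step: the limit of > 250000 nM in this assay, at which 1 of the 3 values shown sits.

Within the data shown here, because the exchange alters the group as a whole, with fewer heavy atoms, more hydrogen-bond acceptors and a defined stereocentre entering together, the single step cannot assign the loss to any one of these features. On these data alone, it remains open how a carboxylic acid in place of the methyl ester, a longer chain between the amine and the ester, or the opposite configuration at the stereocentre would read at this position.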